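This account rests on a few compounds, and the source may have more. Where it says the series, first, only, none or still open, it means among the compounds named here.

The measured compounds are these:

compound 1 `CCC(C(=O)N1CCN(c2ccc(C(F)(F)F)cc2)CC1)N1C(=O)CCC1=O`, which gives 25% in a functional assay on the whole organism (strain Swiss) with Mus musculus as the target, in the maximal electroshock model, with a stated time of 0.25 h, at a dose of 300 mg/kg by the intraperitoneal route; on this read-out lower numbers stand for a weaker effect and higher numbers for a stronger effect at the one dose given;
compound 2 `CCC(C(=O)N1CCN(c2ccccc2)CC1)N1C(=O)CCC1=O`, which gives 75% in this assay;
compound 3 `CCC(C(=O)N1CCN(c2cccc(C(F)(F)F)c2)CC1)N1C(=O)CCC1=O`, which gives 75% in this assay.

Compound 2 stands level with compound 3, and the two together give the highest numbers of the three. Its distance from compound 1 is large: a number 50 percentage points higher from compound 1 to compound 2 (beyond the scatter). From compound 2 to compound 3 the number does not move: no change at the digits printed from compound 2 to compound 3 (within the scatter).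

Compound 4 `CCC(C(=O)N1CCN(c2ccccc2Cl)CC1)N1C(=O)CCC1=O` is not yet measured. It differs from compound 2 in one place:

chloro in place of hydrogen on an aromatic carbon

Neither measured step concerns a chloro group, and neither concerns a position ortho to a large group, so both bear on this change only loosely. They show that one substituent on the aromatic ring left the number unchanged while another cut it sharply, so the direction for compound 4 is open. The estimate for compound 4 is 60%, within 25% to 90%, which means an expected step of a number 15 percentage points lower from compound 2 to compound 4 (beyond the scatter).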

Compound 4, a percentage reported as activity, at one dose (the size of the read-out at that dose, not a potency): 50%
Compound 4: middle estimate off by 10 percentage points, on the high side; measured number inside the range.
By their numbers in this assay, from the lowest: compound 1; then compound 4; then compounds 2 and 3 (each within the scatter of the next).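

In this assay, the change from phenyl to 2-chlorophenyl gives a number 25 percentage points lower from compound 2 to compound 4 (beyond the scatter), so a single chlorine atom ortho to a large group is enough to move the number beyond the scatter. The ring now carries one substituent that leaves the number level with the unsubstituted compound 2, the trifluoromethyl of compound 3, and two that go with lower numbers, the trifluoromethyl of compound 1 and the chloro of compound 4. Nothing available here gives a reason for this drop.

The compounds shown leave open whether the drop belongs to the chloro group itself or to its place on the ring. A fluoro atom or a methoxy group ortho to the same large group could separate the two, as could chloro at another ring carbon.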